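Pyrazolyl for oxazolyl: the step from compound 1 to compound 3

This account rests on a few compounds, and the source may have more. Where it says the series, first, only, none or still open, it means among the compounds named here.

Compound 1 `Cc1noc(C)c1-c1cnc(N)c(Oc2ccc(C(=O)Nc3ccccc3Cl)cc2)n1` and compound 2 `Cc1noc(C)c1-c1cnc(N)c(Oc2ccc(C(=O)Nc3cc(Cl)ccn3)cc2)n1` share a core and differ only at the amide-type nitrogen. In a functional assay on U-87MG ATCC cells for inhibition, with U-87 MG (Homo sapiens) as the target, read by MTT assay, with a stated time of 72 h (a higher number here means a weaker inhibitor, a lower number a stronger inhibitor), compound 1 gives 60500 nM, and compound 2 gives 70800 nM. For the measured compounds named here, the single measured step, a 1.2-fold higher number from compound 1 to compound 2 (0.07 log units; within the scatter), lies within the scatter, so compound 1 holds the lowest of the two numbers without standing apart from compound 2.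

Compound 3 `Cn1cc(-c2cnc(N)c(Oc3ccc(C(=O)Nc4ccccc4Cl)cc3)n2)cn1` differs from compound 1 at another place: 1-methyl-1H-pyrazol-4-yl in place of 3,5-dimethyl-1,2-oxazol-4-yl on an aromatic carbon. No measured step touches this position; the only step shown concerns the amide-type nitrogen and is itself within the scatter, so it says little about a change on the core. With both measured compounds weak in this assay, and nothing to indicate a move in either direction, the expected step of a 1.0-fold lower number from compound 1 to compound 3 (0.00 log units; within the scatter) is none beyond the scatter, with a wide range to allow for the unknown. Compound 3 is therefore estimated at 60000 nM, between 15000 nM and 200000 nM.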

Compound 3, half-maximal inhibitory concentration: 44800 nM
The estimate for compound 3 lay 1.3-fold (0.13 log units) above the measured number; low and high end bracket the measured number.
By their numbers in this assay, from the lowest: compounds 3, 1 and 2 (each within the scatter of the next).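

In this assay the change reads as a 1.4-fold lower number from compound 1 to compound 3 (0.13 log units; within the scatter), so 1-methyl-1H-pyrazol-4-yl in place of 3,5-dimethyl-1,2-oxazol-4-yl, on the aromatic carbon para to an amino group, gives no step beyond the scatter. Compound 3 is the only compound shown that alters this position, and it adds a second place on the molecule to the amide-type nitrogen, where the one earlier step also lay within the scatter; across these two single changes the number does not leave the scatter. The exchange keeps one five-membered aromatic ring with 2 hetero atoms in this place, going from 7 heavy atoms to 6, and nothing available here explains how the two groups compare in this assay.

The compounds shown leave open whether a group of another kind on this carbon, such as a phenyl ring, a morpholine or a simple amine, would move the number beyond the scatter. They also leave open how 1-methyl-1H-pyrazol-4-yl would read together with 4-chloropyridin-2-yl on the amide-type nitrogen.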